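Chain length on the shared core: cytotoxicity working notes

The source may report more compounds than this note shows. Statements on the series, on what has been measured and on what is new or still open speak of the compounds shown alone.

Measured so far:
compound 1, `CCCCCCCCCCCCC/C=C/[C@@H](O)[C@H](CO)n1cc(CCCCCC)nn1` — 8200 nM
compound 2, `CCCCCCCCCCCCCCCCCCCCCCCCc1cn([C@@H](CO)[C@H](O)[C@H](O)CCCCCCCCCCCCCC)nn1` — > 50000 nM

Two compounds have been run in a functional assay on K562 cells (Homo sapiens) for cytotoxicity, read by MTT assay; on this read-out higher numbers stand for an effect only at larger amounts of compound and lower numbers for an effect already at smaller amounts. Within the data shown here, compound 1 gives 8200 nM, which is the only number obtained to date. Compound 2 returns no number but a limit of the assay, > 50000 nM. That limit is described by the limit of > 50000 nM in this assay, at which 1 of the 2 values shown sits. Compound 2 differs from compound 1 in several places at once, so nothing can be read from the pair about any single change.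

Compound 3, `CCCCCCCCCCCCC/C=C/[C@@H](O)[C@H](CO)n1cc(CCC)nn1`, differs from compound 1 in one place: hydrogen in place of propyl on a saturated chain carbon, three bonds along the chain from an aromatic carbon. Read one bond further out, it is hexyl to propyl. Among the measured compounds shown here, no measured pair shows what such a change does on this core, so the size of the step is uncertain. The expectation is a small loss that may stay within the scatter, with the step from a 1.7-fold higher number from compound 1 to compound 3 (0.23 log units; within the scatter) expected. Compound 3 is therefore estimated at 14000 nM, within a range of 5000 nM to 45000 nM.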

Compound 3, half-maximal effective concentration: 13000 nM
Estimate against measurement, compound 3: 1.1-fold (0.03 log units) above, within the range that was stated.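

Among these compounds, compound 3 supplies the first comparison on the shared core that differs in one place: in this assay, going from hexyl to propyl gives a 1.6-fold higher number from compound 1 to compound 3 (0.20 log units; within the scatter) and thus stays inside the usual variation of repeated measurements. At this position, on this read-out, the hexyl and propyl chains therefore cannot be told apart, so shortening the chain to this extent has no effect that can be resolved here. This holds for this one pair only and does not yet describe a trend along the chain. No information at hand bears on why the two chains read alike.

Still open, on these data alone, is what happens at this position with a longer chain such as decyl, or with an amine or a carboxylic acid at the end of a short chain, any of which would show whether the position responds to change at all. Compound 2 gives only a limit, > 50000 nM, and it differs from compound 1 in several places, so the contribution of each of its changes also remains unresolved.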